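Trimming the Pentyl Ether Chain by One Carbon

The source may hold more compounds than are shown below. What is called first, only, known or untested is meant among the compounds shown, and "the series" means these compounds.

Compound 1 `CCCCCOC1(c2ccc(Cl)cc2)SC=C(C)n2c1noc2=O`: > 100000 nM
Compound 2 `CC/C=C/COC1(c2ccc(Br)cc2)SC=C(C)n2c1noc2=O`: 111000 nM

In a functional assay on A2780/DX3 cells (Homo sapiens) for antiproliferative activity, read by MTT assay, with a stated time of 3 days (a higher number here means a weaker inhibitor, a lower number a stronger inhibitor), compound 1 gives > 100000 nM, which is a limit of the assay and not a number. In this assay compound 2 gives 111000 nM. Compound 1 therefore stands at the edge of what was measured, at the limit of > 100000 nM in this assay, at which 1 of the 2 values shown sits. Compound 3 `CCCCOC1(c2ccc(Cl)cc2)SC=C(C)n2c1noc2=O` differs from compound 1 by hydrogen in place of methyl on a saturated chain carbon, four bonds along the chain from an oxygen on a saturated carbon. For the measured compounds named here, with no measured step to lean on, the expected step is a number no higher from compound 1 to compound 3 (the limit leaves the size open), none beyond the scatter. Compound 3 is expected to give about 100000 nM, between 40000 nM and 300000 nM, most likely again only as a limit.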

Compound 3, half-maximal inhibitory concentration: 49000 nM
Compound 3: the middle estimate sits 2.0-fold (0.31 log units) above what was measured, within the range that was stated.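

In this assay compound 1 gives > 100000 nM, a limit and not a number. Hydrogen in place of methyl, four bonds along the chain from an oxygen on a saturated carbon, gives an at least 2.0-fold lower number from compound 1 to compound 3 (0.30 log units; that floor lies within the scatter), so this change turns a limit into a read value. The true size of the step stays unread: the limit of > 100000 nM in this assay, at which 1 of the 3 values shown sits.

Going by these compounds, whether a still shorter propyl or ethyl chain would move the number further remains open. So does what an amine in place of the ether chain would do.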